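Piperazine alkyl trimming in the tetrahydroquinoline series

The compounds below may be only part of what the source reports. "The series", "measured", "known", "first", "only" and "open" are said of these compounds alone.

Measured so far:
- compound 1 `c1cnc2c(c1)CCC[C@@H]2N(CC1CCCCC1)C[C@H]1Cc2c(cccc2N2CCNCC2)CN1`: 81.6%
- compound 2 `CCN1CCN(c2cccc3c2C[C@H](CN(C)[C@H]2CCCc4cccnc42)NC3)CC1`: 0%

In an ADME assay on microsomes from liver (Homo sapiens) for metabolic stability, read by LC-MS, with a stated time of 10 min (on this read-out higher numbers stand for a more stable compound and lower numbers for a less stable compound), compound 1 gives 81.6%. In this assay compound 2 gives 0%, the lower of the two numbers; the gap to compound 1 is beyond the usual scatter of this read-out. Among the measured compounds shown here, no step between compounds that differ in a single place is available, so the two values show only how far apart these two unrelated structures lie.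

Compound 3 `CN1CCN(c2cccc3c2C[C@H](CN(C)[C@H]2CCCc4cccnc42)NC3)CC1` is not yet measured. It differs from compound 2 in one place: hydrogen in place of methyl on a saturated chain carbon bound to an amine nitrogen in a ring. The change removes a single carbon from the chain on the piperazine nitrogen, and nothing in the measured pair speaks to that change directly. Compound 2 sits at the floor of the read-out, so any movement can only go upward, and the step from compound 2 to compound 3 is expected to be small, a number 5 percentage points higher from compound 2 to compound 3 (within the scatter), within or near the scatter. Compound 3 is therefore expected to give about 5%, in the range 0% to 20%.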

Compound 3, percent of the compound remaining: 75.8%
Estimate against measurement, compound 3: 70.8 percentage points below; measured number above the stated range.
By their numbers in this assay, from the lowest: compound 2; then compounds 3 and 1 (each within the scatter of the next).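

Trimming 4-ethylpiperazin-1-yl to 4-methylpiperazin-1-yl gives a number 75.8 percentage points higher from compound 2 to compound 3 (beyond the scatter) in this assay with the rest of the structure unchanged. The earlier pair could not tie the gap in this read-out to any single place, whereas this step shows that one carbon in the chain on the piperazine nitrogen can separate a compound at the floor of the read-out from a far higher value. Among the compounds shown here, nothing measured so far bears on the reason for this step.

Still open, from the compounds shown here alone, is how a longer chain such as propyl, or a cyclopropyl or acetyl group, on the same piperazine nitrogen would read in this assay. Also open, going by these compounds, is whether the ethyl to methyl change gives a step of similar size when the other substituents on the shared core differ.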